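The source may hold more compounds than are shown below. What is called first, only, known or untested is meant among the compounds shown, and "the series" means these compounds.

In a functional assay on CCRF-CEM cells (Homo sapiens) for antiproliferative activity, read by cell counting, with a stated time of 2 days (on this read-out higher numbers stand for weaker inhibition and lower numbers for stronger inhibition), compound 1 `COc1ccc(C(=O)c2sc(Nc3ccccc3)nc2N)cc1OC` gives 6900 nM. Compound 2 `COc1ccc(C(=O)c2sc(Nc3ccc(F)cc3)nc2N)cc1` reaches only > 10000 nM, which is a limit of the assay and not a number. Compound 3 `COc1cccc(C(=O)c2sc(Nc3ccccc3)nc2N)c1` gives 2300 nM.

Among the compounds with values here, the single measured step is a 3.0-fold lower number from compound 1 to compound 3 (0.48 log units; beyond the scatter), modest yet beyond the scatter, and it leaves compound 3 with the lowest of the two numbers. Compound 4 `COc1ccc(Nc2nc(N)c(C(=O)c3cccc(OC)c3)s2)cc1` differs from compound 3 in one place: methoxy in place of hydrogen on an aromatic carbon; cut one bond further out this reads phenyl to 4-methoxyphenyl. Within the data shown here, no measured step touches this ring, and compound 2 differs from compound 3 in two places, so it gives no direct guide. Compound 4 is therefore expected to show a step of a 1.5-fold higher number from compound 3 to compound 4 (0.18 log units; within the scatter). Compound 4 is estimated at 3500 nM, between 1200 nM and 10000 nM.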

Compound 4, half-maximal inhibitory concentration: 9.9 nM
For compound 4 the middle estimate is 350-fold (2.55 log units) above the measured one; measured number below the stated range.
By their numbers in this assay, from the lowest: compound 4; then compound 3; then compound 1. At a limit, above all of these: compound 2.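

Placing methoxy on the phenyl group, para to a large group, gives a 230-fold lower number from compound 3 to compound 4 (2.37 log units; beyond the scatter) in this assay and so shows that this position, unchanged among the earlier compounds with measured numbers, can shift the result far more than the only earlier step of a 3.0-fold lower number from compound 1 to compound 3 (0.48 log units; beyond the scatter) did. Nothing given here accounts for the size of this change.

On these data alone, whether a hydroxyl, an amine or an ethoxy group at this same position would keep such a low number stays open. So does whether methoxy elsewhere on this phenyl group would do the same.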